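The source may report more compounds than this note shows. Statements on the series, on what has been measured and on what is new or still open speak of the compounds shown alone.

Measured in a functional assay on K562 cells (Homo sapiens) for antiproliferative activity, read by MTT assay and trypan blue exclusion, with a stated time of 72 h; a lower number here means a stronger inhibitor, a higher number a weaker inhibitor:
compound 1 `COC(=O)c1ccc(C2SCC(=O)N2c2ccc(N3CCN(S(=O)(=O)c4ccc(F)cc4)CC3)cn2)c(OC)c1`: > 100000 nM.
compound 2 `COC(=O)c1ccc(C2SCC(=O)N2c2ccc(N3CCN(Cc4ccc(Cl)c(Cl)c4)CC3)cn2)c(OC)c1`: > 100000 nM.
compound 3 `COC(=O)c1ccc(C2SCC(=O)N2c2ccc(N3CCN(S(=O)(=O)c4ccc(OC)cc4)CC3)cn2)c(OC)c1`: 54500 nM.

Compound 1 has an entry that is a limit of the assay, not a number. Compound 2 has an entry that is likewise a limit. Among the measured compounds shown here, two of the three entries thus sit at the limit of > 100000 nM in this assay, at which 2 of the 3 values shown sit, and compound 3 is the only member of the set with a readable number in this assay.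

Compound 4 `COC(=O)c1ccc(C2SCC(=O)N2c2ccc(N3CCN(S(=O)(=O)c4c(C)cc(C)cc4C)CC3)cn2)c(OC)c1` differs from compound 3 by 2,4,6-trimethylphenyl in place of 4-methoxyphenyl on a sulfonyl sulfur. The measured steps that touch the same group on the sulfonyl sulfur are an at least 1.8-fold lower number from compound 1 to compound 3 (0.26 log units; that floor lies within the scatter) and an at least 1.8-fold lower number from compound 2 to compound 3 (0.26 log units; that floor lies within the scatter); both are only floors, and the step that the two limits leave unreadable from compound 1 to compound 2 gives no size at all. So far, then, changes on this arm have moved the number little, and the 4-methoxyphenyl compound alone yields a number. Removing that methoxy group in compound 4 is expected to return the value toward the limit, and the expected step is a 1.6-fold higher number from compound 3 to compound 4 (0.19 log units; within the scatter), with a fair chance that only a limit is reported. For compound 4 the estimated value is 85000 nM, with a range from 30000 nM to 200000 nM.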

Compound 4, half-maximal inhibitory concentration: 53500 nM
Beside the measured number, compound 4's estimate is 1.6-fold (0.20 log units) above it; low and high end bracket the measured number.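

In this assay, the 4-methoxyphenyl group on the sulfonyl sulfur is no longer alone in giving a readable number, since 2,4,6-trimethylphenyl also gives one: a 1.0-fold lower number from compound 3 to compound 4 (0.01 log units; within the scatter). Readable numbers at this position therefore do not depend on the methoxy group, and the two aryl groups cannot be told apart here. Measured against the compounds at the limit, the steps are floors only, an at least 1.8-fold lower number from compound 2 to compound 4 (0.27 log units; that floor lies within the scatter) and an at least 1.8-fold lower number from compound 1 to compound 4 (0.27 log units; that floor lies within the scatter), so neither shows a change beyond the scatter.

From the compounds shown here alone, it remains open whether any group on the sulfonyl sulfur can move the number beyond the scatter, for example a simple alkyl chain or a phenyl ring bearing an amine. Going by these compounds, how the number responds to a carboxylic acid in place of the methyl ester on the core also remains open.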